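This account rests on a few compounds, and the source may have more. Where it says the series, first, only, none or still open, it means among the compounds named here.

Of the compounds shown here, three from one series have so far been measured in a functional assay on HCT-116 cells (Homo sapiens) for cytotoxicity, read by MTT assay, with a stated time of 72 h; a lower number here means a stronger inhibitor, a higher number a weaker inhibitor. Compound 1, `COc1ccc(-c2cc(/N=C3/NC(=O)CS3)cs2)cc1`, gives > 50000 nM, which is a limit of the assay rather than a number. Compound 2, `O=C1CS/C(=N\c2csc(-c3ccc(Cl)cc3)c2)N1`, gives > 50000 nM, again a limit and not a number. The step from compound 1 to compound 2 is a chloro in place of methoxy on an aromatic carbon, and a step that the two limits leave unreadable from compound 1 to compound 2. Compound 3, `O=C1N/C(=N/c2csc(-c3ccc(Cl)cc3)c2)S/C1=C\c1ccccc1`, gives 11200 nM in this assay and is therefore the only one of the three to come with a number. The other two values sit at the limit of > 50000 nM in this assay, at which 2 of the 3 values shown sit.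

Compound 4, `CN(C)c1ccc(/C=C2\S/C(=N\c3csc(-c4ccc(Cl)cc4)c3)NC2=O)cc1`, has not yet been measured. It differs from compound 3 by dimethylamino in place of hydrogen on an aromatic carbon. Going by the values given here, no measured step touches the same part of the structure: the only step between measured compounds, that from compound 1 to compound 2, has no readable size, so nothing measured sets the size of the change from compound 3 to compound 4. Of compound 2 and compound 3 no more can be said than what their two values show. For compound 4 the estimated step is a 1.9-fold lower number from compound 3 to compound 4 (0.27 log units; within the scatter). Compound 4 is therefore expected to give 6000 nM in this assay, with a range from 2000 nM to 25000 nM.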

Compound 4, half-maximal inhibitory concentration: 500 nM
Compound 4: middle estimate off by 12-fold (1.08 log units), on the high side, outside the stated range (below it).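

In this assay, going by these compounds alone, dimethylamino in place of hydrogen on an aromatic carbon, para to a large group, gives a 22-fold lower number from compound 3 to compound 4 (1.35 log units; beyond the scatter), and this is the first step whose size can be read. Within the data shown here, it shows that this position on the phenyl group is not silent, since the change from phenyl to 4-(dimethylamino)phenyl alone moves the number well beyond the usual scatter, something the earlier compounds, with no readable step among them, could not show. Nothing measured here bears on why the number falls with this change.

The compounds shown leave open whether a like step would come with a primary amine, a morpholine or a carboxylic acid on the same aromatic carbon, or whether it belongs to dimethylamino in particular. Also open, from the compounds shown here alone, is whether the step would hold with methoxy in place of chloro on the other aromatic ring, the difference that separates compound 1 from compound 2, whose two values in this assay are limits and not numbers.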